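Chloropyridyl for methylpyrazinyl: clearance expectation for compound 4

The compounds below may be only part of what the source reports. "The series", "measured", "known", "first", "only" and "open" are said of these compounds alone.

Compound 1 `Cc1ccc(-c2ccc(Cl)c(C(=O)NCC3(O)CCCCCC3)c2)nn1` gives 23 mL/min/kg in an in vitro ADME assay on microsomes from liver (Homo sapiens) for metabolic stability; on this read-out lower numbers stand for slow clearance and higher numbers for fast clearance. Compound 2 `Cc1cnc(-c2ccc(Cl)c(C(=O)NCC3(O)CCCCCC3)c2)cn1` gives 36 mL/min/kg in this assay, the step of a 1.6-fold higher number from compound 1 to compound 2 (0.19 log units; within the scatter) carrying a 5-methylpyrazin-2-yl in place of 6-methylpyridazin-3-yl on an aromatic carbon. For compound 3 `O=C(NCC1(O)CCCC(F)(F)CC1)c1cc(-c2ncc(F)cn2)ccc1Cl` the read-out in this assay is a limit, < 8 mL/min/kg (the limit of < 8 mL/min/kg in this assay, at which 1 of the 3 values shown sits). Compound 2 thus stands together with compound 1, its nearest neighbour, the two not set apart by the scatter; the third value shown is a limit, and compound 3 also differs from compound 2 in more than one place.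

Compound 4 `O=C(NCC1(O)CCCCCC1)c1cc(-c2ccc(Cl)cn2)ccc1Cl` is not yet measured. The change is 5-chloropyridin-2-yl in place of 5-methylpyrazin-2-yl on an aromatic carbon. Going by the values given here, the only measured step of the same kind, a swap of one six-membered heteroaryl for another on the same carbon, is a 1.6-fold higher number from compound 1 to compound 2 (0.19 log units; within the scatter), within the scatter. No step is expected beyond the scatter, in either direction. The expected step is therefore a 1.1-fold lower number from compound 2 to compound 4 (0.05 log units; within the scatter). For compound 4 the estimate in this assay is 32 mL/min/kg, ranging from 12 mL/min/kg to 80 mL/min/kg.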

Compound 4, clearance: 52 mL/min/kg
Compound 4: middle estimate off by 1.6-fold (0.21 log units), on the low side; measured number inside the range.
By their numbers in this assay, from the lowest: compounds 1, 2 and 4 (each within the scatter of the next, the first and the last beyond it). At a limit, below all of these: compound 3.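

In this assay, 5-chloropyridin-2-yl, with one hetero atom in the ring, cannot be told apart from 5-methylpyrazin-2-yl, with two, at this place para to a chloro group: a 1.4-fold higher number from compound 2 to compound 4 (0.16 log units; within the scatter). Set against 6-methylpyridazin-3-yl, the same group gives the first step at this position that clears the scatter, a 2.3-fold higher number from compound 1 to compound 4 (0.35 log units; beyond the scatter), so the choice of heteroaryl here can shift clearance, though only modestly, while compound 2 stays within the scatter of both neighbours. No measurement at hand bears on why these swaps differ.

Open, as far as these compounds go, is whether an amine or a methoxy group in place of the chloro or methyl substituent on this ring would keep clearance in the same range. Also open, from the compounds shown here alone, is whether the same swap gives a similar step on the core of compound 3.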